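Amino group on the core weakens growth inhibition

The source may hold more compounds than are shown below. What is called first, only, known or untested is meant among the compounds shown, and "the series" means these compounds.

Compound 1, `ClCc1ccc(Cn2cnc3c(Cl)ncnc32)cc1`: 4570 nM
Compound 2, `Nc1nc(Cl)c2ncn(Cc3ccc(CCl)cc3)c2n1`: 25100 nM
Compound 3, `ClCc1ccccc1Cn1cnc2c(Cl)ncnc21`: 10500 nM

These three compounds were tested in a functional assay on UO-31 cells (Homo sapiens) for cytotoxicity, read by sulforhodamine B assay, with a stated time of 48 h; a higher number here means a weaker inhibitor of growth, a lower number a stronger inhibitor of growth. Compound 2 differs from compound 1 by a single change: amino in place of hydrogen on an aromatic carbon. That change made a 5.5-fold higher number from compound 1 to compound 2 (0.74 log units; beyond the scatter), so the amino group weakened growth inhibition. Compound 3 is built from the same atoms as compound 1, joined differently; the difference between the two cores is not broken down here. In this assay compound 3 stands between the other two, giving a higher number than compound 1 and a lower number than compound 2.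

Compound 4, `Nc1nc(Cl)c2ncn(Cc3ccccc3CCl)c2n1`, has not yet been measured in this assay. Among the measured compounds shown here, it differs from compound 3 by amino in place of hydrogen on an aromatic carbon, which is the same change as the one from compound 1 to compound 2, at the same kind of place on the core. This very change made a 5.5-fold higher number from compound 1 to compound 2 (0.74 log units; beyond the scatter), so a step of similar size is expected from compound 3 to compound 4. Compound 4 is therefore expected to give about 50000 nM, estimated to lie between 20000 nM and 130000 nM, which means an expected step of a 4.8-fold higher number from compound 3 to compound 4 (0.68 log units; beyond the scatter).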

Compound 4, concentration for total growth inhibition: 44700 nM
Beside the measured number, compound 4's estimate is 1.1-fold (0.05 log units) above it; the measured number falls inside the stated range.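

In this assay the amino group in place of hydrogen again weakened growth inhibition, giving a 4.3-fold higher number from compound 3 to compound 4 (0.63 log units; beyond the scatter). Set beside the earlier step, the change carried over from the core of compound 1 to the core of compound 3 at much the same size, and the gap between the two steps is too small to count as a real difference: the same change on two cores in this assay, a 5.5-fold higher number (0.74 log units; beyond the scatter) from compound 1 to compound 2 and a 4.3-fold higher number (0.63 log units; beyond the scatter) from compound 3 to compound 4, 1.3-fold (0.11 log units) apart, within the scatter of two such steps This rests on only two matched pairs in a single cell line, so it does not show that the amino group would act the same way on any other core, and it does not explain why growth inhibition weakens.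

The compounds shown leave open whether only the amino group weakens growth inhibition from this place between two ring nitrogen atoms, or whether a methylamino group or a hydroxyl group there would do the same. They also leave open whether the same step would appear in other cell lines.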